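Methoxy addition on the amide aryl ring, two cores

This account rests on a few compounds, and the source may have more. Where it says the series, first, only, none or still open, it means among the compounds named here.

The series is read in a functional assay on MDA-MB-231 cells (Homo sapiens), read by microscopy and transwell migration, with a stated time of 24 h; on this read-out lower numbers stand for stronger inhibition and higher numbers for weaker inhibition. Compound 1 `COc1cc(-c2cs/c(=N\C(=O)c3ccccc3)n2C)cc(OC)c1OC` gives 1070 nM. Compound 2 `COc1ccc(C(=O)/N=c2\scc(-c3cc(OC)c(OC)c(OC)c3)n2C)cc1` gives 8040 nM. The change is methoxy in place of hydrogen on an aromatic carbon; the step is a 7.5-fold higher number from compound 1 to compound 2 (0.88 log units; beyond the scatter). Compound 3 `COc1ccc(C(=O)N(C)c2nc(-c3cc(OC)c(OC)c(OC)c3)cs2)cc1OC` carries a second core; the difference between the two cores is not broken down here. In this assay compound 3 gives only a limit, > 25000 nM, as noted in the limit of > 25000 nM in this assay, at which 1 of the 3 values shown sits. Compound 4 `COc1cc(C(=O)N(C)c2nc(-c3cc(OC)c(OC)c(OC)c3)cs2)cc(OC)c1OC` is not yet measured. The change is methoxy in place of hydrogen on an aromatic carbon, the same kind of change as before, not the same: here the entering group is ortho to a methoxy group, meta to a large group and meta to a methoxy group, not para to a large group. Compound 4 is expected at 60000 nM. The expected step is a step that the limit leaves unreadable from compound 3 to compound 4, resting on a 7.5-fold higher number from compound 1 to compound 2 (0.88 log units; beyond the scatter) and on (the limit of > 25000 nM in this assay, at which 1 of the 3 values shown sits).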

Compound 4, half-maximal inhibitory concentration: 470 nM
The estimate for compound 4 lay 130-fold (2.11 log units) above the measured number, outside the stated range (below it).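

In this assay, methoxy in place of hydrogen on an aromatic carbon gives an at least 53-fold lower number from compound 3 to compound 4 (1.72 log units; beyond the scatter), a step opposite in direction to the one seen on the core of compound 1. Compound 3 gives only > 25000 nM, which is a limit of the assay and not a number. The change therefore does not carry over as one constant step between these two cores, but one pair per core, with the methoxy entering at a different place in each pair, cannot separate the effect of the core from that of the place: the same change on two cores in this assay, a 7.5-fold higher number (0.88 log units; beyond the scatter) from compound 1 to compound 2 and an at least 53-fold lower number (1.72 log units; beyond the scatter) from compound 3 to compound 4, at least 390-fold (2.60 log units) apart, beyond the scatter of two such steps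

Still open, on these data alone, is how an amine or a hydroxy group in place of this methoxy would read on the core of compound 4. Also open, as far as these compounds go, is how the methoxy pattern of compound 4 would read on the core of compound 1.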